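Amide variation at the triazole-linked carbonyl of the shared core

A few compounds are considered here, and "the series" means these few. Any claim that something is new, unique, unknown or untested is made for them only; others in the source may bear on it.

Compound 1 `O=C1C(=O)N(Cc2cn(CC(=O)N3CCNCC3)nn2)c2c(Cl)ccc(Cl)c21` carries a (piperazin-1-yl)carbonyl group; in a functional assay on MCF7 cells (Homo sapiens) for inhibition, read by CCK-8 assay, with a stated time of 72 h (a higher number here means a weaker inhibitor, a lower number a stronger inhibitor), compound 1 returned "nd(insoluble)" (no result reported), so no number places it within the series. Two measured analogues vary the same carbonyl position: compound 2 `O=C(Cn1cc(CN2C(=O)C(=O)c3c(Cl)ccc(Cl)c32)nn1)Nc1ccccc1` gives 38500 nM in this assay, and compound 3 `O=C1C(=O)N(Cc2cn(CC(=O)N3CCCCC3)nn2)c2c(Cl)ccc(Cl)c21` gives 34600 nM. Among the measured compounds shown here, the one measured step, a 1.1-fold lower number from compound 2 to compound 3 (0.05 log units; within the scatter), shows that exchanging the amine on this carbonyl carbon left the read-out essentially unchanged.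

Compound 4 `O=C(Cn1cc(CN2C(=O)C(=O)c3c(Cl)ccc(Cl)c32)nn1)NC1CCCCC1` is the cyclohexylcarbamoyl analogue; relative to compound 1 the change is cyclohexylamino in place of piperazin-1-yl on a carbonyl carbon. The step from compound 2 to compound 3 is the only one that bears on it, and it stayed within the scatter, so nothing here argues for a change beyond the scatter when compound 4 is measured. Compound 4 is expected to sit with compounds 2 and 3 in this assay, estimated at 36000 nM with a range of 15000 nM to 90000 nM.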

Compound 4, half-maximal inhibitory concentration: 51800 nM
Estimate against measurement, compound 4: 1.4-fold (0.16 log units) below; the range from low to high includes it.
By their numbers in this assay, from the lowest: compounds 3, 2 and 4 (each within the scatter of the next).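

In this assay, cyclohexylamino reads against piperidin-1-yl as a 1.5-fold higher number from compound 3 to compound 4 (0.18 log units; within the scatter) and against anilino, with cyclohexyl in place of phenyl on the amide-type nitrogen, as a 1.3-fold higher number from compound 2 to compound 4 (0.13 log units; within the scatter) and so stays level with both. The position therefore now holds three amides with no separation: neither replacing the phenyl ring with a carbon-only non-aromatic ring nor the presence of the amide hydrogen in compounds 2 and 4, and its absence in compound 3, sets any compound apart. Nothing available bears on why the read-out stays flat at this position.

Compound 1, at "nd(insoluble)" (no result reported), still leaves the piperazin-1-yl group unplaced. Also open, as far as these compounds go, is whether a benzylamino group or an amine on a longer chain at this carbonyl carbon would move the number beyond the scatter.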